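This account rests on a few compounds, and the source may have more. Where it says the series, first, only, none or still open, it means among the compounds named here.

Compound 1 `CN1CCC[C@H]1COc1cccnc1Br`: 451 nM
Compound 2 `CN1CCC[C@H]1COc1cncc(Br)c1`: 0.27 nM
Compound 3 `CN1CCC[C@H]1COc1cc(Br)c[n+]([O-])c1`: 34.8 nM

These three compounds were measured in an assay on membranes from brain for displacement of a labelled ligand from Neuronal acetylcholine receptor; alpha4/beta2 (Rattus norvegicus); on this read-out lower numbers stand for stronger inhibition and higher numbers for weaker inhibition. Compound 2 gives the lowest number of the three; compound 3 stands nearest to it and compound 1 furthest, and both gaps lie well beyond the usual scatter, so compound 2 binds most strongly here.

Compound 4 `CN1CCC[C@H]1COc1cncc(N)c1` has not yet been measured. It differs from compound 2 in one place: amino in place of bromo on an aromatic carbon.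

Among the compounds with values here, no measured pair shows this exchange of bromo for amino, so the size of the step can only be guessed. The expectation is a clearly higher number in this assay than compound 2 shows, a step of a 30-fold higher number from compound 2 to compound 4 (1.47 log units; beyond the scatter). For compound 4 the estimated value in this assay is 8 nM, with a likely range from 1.5 nM to 40 nM.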

Compound 4, inhibition constant: 0.63 nM
Estimate against measurement, compound 4: 13-fold (1.10 log units) above; the measured number lies below the stated range.
By their numbers in this assay, from the lowest: compound 2; then compound 4; then compound 3; then compound 1.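

In this assay, amino in place of bromo on this aromatic carbon costs little: the exchange gives a 2.3-fold higher number from compound 2 to compound 4 (0.37 log units; beyond the scatter), a modest step though beyond the scatter. So a low number at this position, two atoms from the ring nitrogen, does not depend on bromo, since amino, which carries a hydrogen-bond donor, also gives one. No measurement at hand explains why the step is so small. As far as these compounds go, whether a larger group at this place, such as a methylamino group, an acetamide or a carboxylic acid, would keep the number this low remains open.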